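A few compounds are considered here, and "the series" means these few. Any claim that something is new, unique, unknown or untested is made for them only; others in the source may bear on it.

Compound 1, `CC(C)(C)Cn1cc2c(Cl)nc(NC(=O)c3ccc(C(F)(F)F)cc3)nc2n1`, is examined in a functional assay on CHO cells for antagonist activity at adenosine receptor A2b (Homo sapiens), read by 33P incorporation, with a stated time of 20 min, in the presence of a further agent that is not named here; on this read-out lower numbers stand for stronger inhibition and higher numbers for weaker inhibition. In this assay compound 1 gives > 20000 nM, which is a limit of the assay rather than a number. Two relatives share its core and differ only on the aromatic nitrogen. Compound 2, `Cn1cc2c(Cl)nc(NC(=O)c3ccc(C(F)(F)F)cc3)nc2n1`, gives > 20000 nM in this assay, again a limit. Compound 3, `CC(C)n1cc2c(Cl)nc(NC(=O)c3ccc(C(F)(F)F)cc3)nc2n1`, gives > 20000 nM in this assay, also a limit. The steps among these three are therefore a step that the two limits leave unreadable from compound 1 to compound 2, a step that the two limits leave unreadable from compound 1 to compound 3 and a step that the two limits leave unreadable from compound 2 to compound 3; the limit of > 20000 nM in this assay, at which 3 of the 3 values shown sit, describes where all three values sit. Compound 4, `CC(C)(C)Cn1cc2c(Cl)nc(NC(=O)c3ccc(F)cc3)nc2n1`, differs from compound 1 in a different place: fluoro in place of trifluoromethyl on an aromatic carbon. Going by the values given here, none of the measured steps touches the aromatic carbon, so none of them bears on this change, and the three values give no readable size for any step in this assay. The expectation for compound 4 rests only on the fact that every relative sits at the limit. A step of a number no higher from compound 1 to compound 4 (the limit leaves the size open) is expected. Compound 4 is estimated at 20000 nM, between 5000 nM and 80000 nM.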

Compound 4, inhibition constant: > 10000 nM
Compound 4: a limit, no number; the forecaster's own chance of this, stated with the estimate: 75%; the middle value is on the limit's open side.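

Compound 1 and compound 4 both give only a limit, not a number, in this assay, so no step can be read between them. The compounds shown leave open how strongly any of them inhibits, and whether fluoro in place of trifluoromethyl changes that at all.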